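Replacing carbamoyl with pyridin-3-yl on compound 3

A few compounds are considered here, and "the series" means these few. Any claim that something is new, unique, unknown or untested is made for them only; others in the source may bear on it.

Working notes on a small set sharing one core. In a functional assay on the whole organism (strain ICR) for inhibition, with Mus musculus as the target, read by scintillation counting, with a stated time of 16 h, at a dose of 10 mg/kg by the oral route (a higher number here means more inhibition at the dose given (going by the name of the read-out), a lower number less inhibition), compound 1 `CC(=O)Nc1ccc(-c2nnc(C3(c4ccc(Cl)cc4)CCC3)n2C)c(Cl)c1` gives 27%, compound 2 `Cn1c(-c2ccc(C(N)=O)cc2C(N)=O)nnc1C1(c2ccc(Cl)cc2)CCC1` gives 0%, and compound 3 `Cn1c(-c2ccc(C(N)=O)cc2Cl)nnc1C1(c2ccc(Cl)cc2)CCC1` gives 12%. Compound 3 thus stands second of the three, with compound 1 above it and compound 2 below it, both gaps beyond the scatter.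

The two measured steps each touch the same aromatic carbon: a number 15 percentage points lower from compound 1 to compound 3 (beyond the scatter) and a number 12 percentage points higher from compound 2 to compound 3 (beyond the scatter). Both are modest and both involve carbamoyl, but neither introduces an aromatic ring at that position.

Compound 4 `Cn1c(-c2ccc(-c3cccnc3)cc2Cl)nnc1C1(c2ccc(Cl)cc2)CCC1` differs from compound 3 by pyridin-3-yl in place of carbamoyl on an aromatic carbon. No measured step brings in a six-membered aromatic ring in place of carbamoyl, so the earlier steps give only a rough guide: modest movements in either direction are what this position has shown. The step from compound 3 to compound 4 is therefore expected to be a number 3 percentage points higher from compound 3 to compound 4 (within the scatter), with no clear direction beyond the scatter. For compound 4 in this assay the estimate is 15%, with a range from 0% to 40%.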

Compound 4, a percentage reported as inhibition, in the whole organism at one dose (the size of the read-out at that dose, not a potency): 26%
Beside the measured number, compound 4's estimate is 11 percentage points below it; measured number inside the range.
By their numbers in this assay, from the lowest: compound 2; then compound 3; then compounds 4 and 1 (each within the scatter of the next).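

In this assay, within the data shown here, this carbon of the shared core accepts a six-membered aromatic ring, with a number 14 percentage points higher from compound 3 to compound 4 (beyond the scatter), the first step here in which a ring enters in place of carbamoyl. Pyridin-3-yl and acetamido cannot be told apart at this position, with a number 1 percentage points lower from compound 1 to compound 4 (within the scatter), so the hydrogen-bond donor that leaves with carbamoyl is not required to reach this level. No measured evidence available here accounts for the step from carbamoyl to pyridin-3-yl.

Still open, on these data alone, is whether the ring nitrogen of pyridin-3-yl counts, or whether the ring alone carries the step, which a phenyl or pyridin-4-yl group at this carbon would separate. Also open, as far as these compounds go, is how a carboxylic acid or an aminomethyl group would read at this position.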